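The source may report more compounds than this note shows. Statements on the series, on what has been measured and on what is new or still open speak of the compounds shown alone.

Of the compounds shown here, three with a shared core have been measured in an assay on CHO cells with metabotropic glutamate receptor 2 (Homo sapiens) as the target, read by FLIPR; a lower number here means that less compound is needed, a higher number that more compound is needed for the effect. Compound 1 `Cn1c(CN2CCN(c3ccc(C(F)(F)F)cc3)CC2)nc2ccccc21` gives 200 nM in this assay. Compound 3 `Cn1c(CN2CCN(c3ccc(Cl)cc3F)CC2)nc2ccccc21` gives 126 nM in this assay. Compound 2 `FC(F)(F)c1ccc(Cl)nc1N1CCN(Cc2nc3ccccc3[nH]2)CC1` gives 12600 nM in this assay, the highest of the three numbers, and its gaps to both compound 1 and compound 3 lie beyond the usual scatter of repeated measurements, so compound 2 is the least potent of the three.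

The step followed here leads from compound 2 to compound 4 `CCCn1c(CN2CCN(c3nc(Cl)ccc3C(F)(F)F)CC2)nc2ccccc21`, which has not yet been measured in this assay. The change is small in size:

propyl in place of hydrogen on an aromatic nitrogen

Because compound 2 gives 12600 nM while the other two compounds sit far lower, there is room for a downward move. Nothing measured here isolates this particular change, so the direction rests on the gap between compound 2 and the rest rather than on a directly comparable pair. The expected step of an 11-fold lower number from compound 2 to compound 4 (1.02 log units; beyond the scatter) is downward and beyond the scatter. Compound 4 is expected to give about 1200 nM in this assay, with a likely range from 300 nM to 5000 nM.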

Compound 4, half-maximal effective concentration: 2510 nM
For compound 4 the middle estimate is 2.1-fold (0.32 log units) below the measured one; low and high end bracket the measured number.
By their numbers in this assay, from the lowest: compounds 3 and 1 (each within the scatter of the next); then compound 4; then compound 2.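

Going by these compounds alone, this is the first pair in this assay that differs in only one place, and propyl in place of hydrogen on an aromatic nitrogen gives a 5.0-fold lower number from compound 2 to compound 4 (0.70 log units; beyond the scatter). The nitrogen of the five-membered aromatic ring can therefore carry propyl instead of hydrogen with a real gain, meaning that less compound is needed for the effect, although the gain is modest in size and rests on this single pair. Nothing measured here accounts for the step, so it stands as an observation about these two compounds and not as an explanation.

Still open, as far as these compounds go, is whether a longer chain such as butyl, or a chain ending in an amine or a carboxylic acid, would move the number further at this nitrogen, or would reverse the step. Within the data shown here, also open is whether propyl in place of hydrogen would give a step of similar size with the other piperazine-bound groups seen in compound 1 and compound 3, since no single-change pair speaks to that.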